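The compounds below may be only part of what the source reports. "The series", "measured", "known", "first", "only" and "open" are said of these compounds alone.

Measured compounds:
- compound 1 `COc1ccc2c(c1)CCCN2S(=O)(=O)c1ccc(N2CCCC2=O)cc1`, 25 nM
- compound 2 `CN1CCN(S(=O)(=O)c2ccc(N3CCCC3)cc2)c2ccccc21`, 4 nM
- compound 3 `COc1ccc2c(c1)N(C)CCN2S(=O)(=O)c1ccc(N2CCCC2=O)cc1`, 14 nM

In a functional assay on MCF7 cells (Homo sapiens) for antiproliferative activity, read by fluorescence and SYBR Green assay, with a stated time of 24 h (on this read-out higher numbers stand for weaker inhibition and lower numbers for stronger inhibition), compound 1 gives 25 nM, the highest of the three numbers shown. Compound 3 gives 14 nM, and the gap between these two lies within the scatter of repeated measurements, so no order can be drawn between compound 1 and compound 3. Compound 2 gives 4 nM, and here the gap to compound 1 is beyond the scatter, so compound 2 stands at a lower number than compound 1.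

Compound 4 `CC(C)(C)c1ccc2c(c1)CCCN2S(=O)(=O)c1ccc(N2CCCC2=O)cc1` has not yet been measured in this assay. It differs from compound 1 in one place: tert-butyl in place of methoxy on an aromatic carbon. Among the compounds with values here, none of the three measured compounds differ from each other in only one place, so no measured step shows what a change of this kind does in this assay, and the expectation for compound 4 can rest only on the number for compound 1.

Within the data shown here, with nothing among the measured compounds to set a direction, the step from compound 1 to compound 4 is expected to be a 1.2-fold higher number from compound 1 to compound 4 (0.08 log units; within the scatter), that is, none beyond the scatter. Compound 4 is therefore estimated at 30 nM, with a range from 8 nM to 110 nM.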

Compound 4, half-maximal inhibitory concentration: 318 nM
Beside the measured number, compound 4's estimate is 11-fold (1.03 log units) below it, and the stated range ends below it.
By their numbers in this assay, from the lowest: compound 2; then compounds 3 and 1 (each within the scatter of the next); then compound 4.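

In this assay, tert-butyl in place of methoxy on an aromatic carbon gives a 13-fold higher number from compound 1 to compound 4 (1.10 log units; beyond the scatter), a large step beyond the scatter, so this position of the core of compound 1 is not indifferent to the group it carries. The three earlier compounds differed in more than one place and could not show this; here a single change at one place, on the six-membered aromatic ring of carbon only, goes with much weaker inhibition, as methoxy, with 2 heavy atoms and 1 hydrogen-bond acceptor, gives way to tert-butyl, with 4 heavy atoms and 0 hydrogen-bond acceptors. Nothing measured here speaks to why the number moves so far.

Heavy atoms and the hydrogen-bond acceptor change together in this one step, so which of the two goes with the higher number stays open, and a methyl group or a hydroxyl group at the same place would pull them apart. Also open, from the compounds shown here alone, is whether the same change would give a step of similar size on the core of compound 3, or at another place on the ring.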